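Removing one methoxy from the aryl ketone of the chalcone series

The source may hold more compounds than are shown below. What is called first, only, known or untested is meant among the compounds shown, and "the series" means these compounds.

Measured:
compound 1 `COc1cc(-c2cc(/C=C/C(=O)c3ccc(Cl)c(Cl)c3)[nH]n2)cc(OC)c1OC` — 11%
compound 2 `COc1ccc(C(=O)/C=C/c2cc(-c3cc(OC)c(OC)c(OC)c3)n[nH]2)cc1OC` — -91%

In a functional assay on CAKI-1 cells (Homo sapiens) for cytotoxicity, read by sulforhodamine B assay, with a stated time of 48 h, tested at 100 uM (a lower number here means a stronger effect, a higher number a weaker effect of the compound at the concentration tested), compound 2 gives the lowest of the two numbers; its nearest neighbour is compound 1, and the step of a number 102 percentage points lower from compound 1 to compound 2 (beyond the scatter) is large. Compound 3 `COc1ccc(C(=O)/C=C/c2cc(-c3cc(OC)c(OC)c(OC)c3)n[nH]2)cc1` differs from compound 2 by hydrogen in place of methoxy on an aromatic carbon. For the measured compounds named here, no measured step covers the loss of a methoxy group; the only step known concerns a different exchange on the same carbonyl-bound aryl group, so it shows that this aryl matters but not how this change acts. A moderate weakening is expected, a number 41 percentage points higher from compound 2 to compound 3 (beyond the scatter), with wide uncertainty. Compound 3 is estimated at -50%, range -100% to 10%.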

Compound 3, a percentage reported as activity, at one concentration (the size of the read-out at that concentration, not a potency): 1%
Estimate against measurement, compound 3: 51 percentage points below; measured number inside the range.
By their numbers in this assay, from the lowest: compound 2; then compounds 3 and 1 (each within the scatter of the next).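

In this assay the change from 3,4-dimethoxyphenyl to 4-methoxyphenyl gives a number 92 percentage points higher from compound 2 to compound 3 (beyond the scatter) and shows that the strong effect of compound 2 depends on this methoxy, ortho to a methoxy group. The other step, a number 10 percentage points lower from compound 1 to compound 3 (within the scatter), puts the 4-methoxyphenyl ketone level with the 3,4-dichlorophenyl ketone, so one remaining methoxy does not hold the effect. Nothing at hand explains this loss. Still open, going by these compounds, is whether the methoxy itself is required on that carbon: a hydroxyl, a fluorine or an ethoxy group there would test this.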